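Methylation of the pyrazole nitrogen across two cores

The compounds below may be only part of what the source reports. "The series", "measured", "known", "first", "only" and "open" are said of these compounds alone.

Measured compounds:
- compound 1 `CC(Nc1nc(N)nc2ccc(-c3cnn(C4CCNCC4)c3)cc12)c1c(Cl)ccc(F)c1Cl`: 1580 nM
- compound 2 `CC(Nc1ncnc2ncc(-c3cnn(C4CCNCC4)c3)cc12)c1c(Cl)ccc(F)c1Cl`: 17700 nM
- compound 3 `CC(Nc1nc(N)nc2ccc(-c3cnn(C)c3)cc12)c1c(Cl)ccc(F)c1Cl`: 7140 nM

The read-out is a functional assay on SK-BR-3 cells (Homo sapiens) for antiproliferative activity, read by MTT assay, with a stated time of 72 h; a higher number here means a weaker inhibitor, a lower number a stronger inhibitor. Compound 1 and compound 2 carry different cores; the difference between the two cores is not broken down here, and compound 2 gives the highest number of the three. From compound 1 to compound 3 the change is methyl in place of piperidin-4-yl on an aromatic nitrogen, and the step is a 4.5-fold higher number from compound 1 to compound 3 (0.66 log units; beyond the scatter). Compound 4 `CC(Nc1ncnc2ncc(-c3cnn(C)c3)cc12)c1c(Cl)ccc(F)c1Cl` is not yet measured; it differs from compound 2 by methyl in place of piperidin-4-yl on an aromatic nitrogen, the same change made on the core of compound 2. For the measured compounds named here, the step is expected to be a 4.0-fold higher number from compound 2 to compound 4 (0.60 log units; beyond the scatter), resting on the single earlier step of a 4.5-fold higher number from compound 1 to compound 3 (0.66 log units; beyond the scatter) and on compound 2 starting from 17700 nM. Compound 4 is therefore estimated at 70000 nM, within 25000 nM to 200000 nM; a limit rather than a number is plausible.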

Compound 4, half-maximal inhibitory concentration: > 100000 nM
Compound 4 gave a limit, no number (the forecaster's own chance of this, stated with the estimate: 40%); at least 1.4-fold (0.15 log units) between middle value and limit.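

In this assay compound 4 gives > 100000 nM, which is a limit of the assay and not a number. On the core of compound 2, methyl in place of piperidin-4-yl on an aromatic nitrogen gives an at least 5.6-fold higher number from compound 2 to compound 4 (0.75 log units; beyond the scatter), so the direction of the step carries over to this second core. Whether the size of the step also carries over is not shown, and two cores are too few to establish a general rule: the same change on two cores in this assay, a 4.5-fold higher number (0.66 log units; beyond the scatter) from compound 1 to compound 3 and an at least 5.6-fold higher number (0.75 log units; beyond the scatter) from compound 2 to compound 4; the limit leaves it open whether they differ

As far as these compounds go, the size of the step on the core of compound 2 stays open. So does the result with other groups on that aromatic nitrogen, such as an open-chain amine or a 2-hydroxyethyl chain, on either core.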